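The source may report more compounds than this note shows. Statements on the series, on what has been measured and on what is new or still open speak of the compounds shown alone.

Three measured members share one core and differ only in the group on an aromatic carbon of the outer ring: compound 1 `CCCCOc1ccc(-c2c(C)[nH]c(=O)n2C)cc1`, compound 2 `CCCCCCCc1ccc(-c2c(C)[nH]c(=O)n2C)cc1` and compound 3 `Cc1[nH]c(=O)n(C)c1-c1ccc(-c2ccccc2)cc1`. In a functional assay on the whole organism with Rattus norvegicus as the target (a lower number here means that less compound is needed, a higher number that more compound is needed for the effect), compound 1 gives 0.3 mg/kg; compound 2 gives 30 mg/kg; compound 3 gives 0.3 mg/kg. The steps between them are a 100-fold higher number from compound 1 to compound 2 (2.00 log units; beyond the scatter), no change at the digits printed from compound 1 to compound 3 (within the scatter) and a 100-fold lower number from compound 2 to compound 3 (2.00 log units; beyond the scatter). Within the data shown here, compound 3 therefore stands level with compound 1 at the digits given, the two together at the lowest point of the three numbers, and its only step beyond the scatter is the one to compound 2.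

Compound 4 `Cc1[nH]c(=O)n(C2CCCCC2)c1-c1ccc(-c2ccccc2)cc1` is the next member. It differs from compound 3 as follows: cyclohexyl in place of methyl on an aromatic nitrogen. Among the measured compounds shown here, no measured step bears on this change: all three exchange the group on the aromatic carbon, and the aromatic nitrogen has not been varied at all. The direction and size of the step are thus not indicated by any number in hand. Given that, the step of a 3.3-fold higher number from compound 3 to compound 4 (0.52 log units; beyond the scatter) is set as an expectation only, with a wide range around it. For compound 4 in this assay the estimate is 1 mg/kg, within 0.1 mg/kg to 10 mg/kg.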

Compound 4, minimum effective dose: 0.1 mg/kg
The estimate for compound 4 lay 10-fold (1.00 log units) above the measured number, within the range that was stated.
By their numbers in this assay, from the lowest: compound 4; then compounds 1 and 3 (each within the scatter of the next); then compound 2.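

At the aromatic nitrogen, held by methyl in compounds 1 to 3, cyclohexyl brings 6 heavy atoms in place of 1 and one six-membered non-aromatic ring, and in this assay the exchange gives a 3.0-fold lower number from compound 3 to compound 4 (0.48 log units; beyond the scatter) in a step beyond the scatter. Among these compounds, this is the first reading at this position, and it shows that the ring nitrogen of the shared core tolerates a far larger group than methyl in this whole-organism read-out, with the number moving down rather than up. Nothing measured on hand accounts for the lower number.

The compounds shown leave open whether the step belongs to cyclohexyl itself or would also appear with an ethyl, an isopropyl, a cyclopentyl or a benzyl group on the same nitrogen. They also leave open whether cyclohexyl gives a similar step when the outer ring carries butoxy or heptyl instead of phenyl, and how a cyclohexyl bearing an amine or a carboxylic acid would read in this assay at this position.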